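Anilide series: methyl to phenyl at the same position

A few compounds are considered here, and "the series" means these few. Any claim that something is new, unique, unknown or untested is made for them only; others in the source may bear on it.

Compound 3 `COc1ccc2nc(C)cc(OCC(=O)Nc3ccc(C)cc3)c2c1` holds the lowest of the two numbers in an ADME assay on HepG2 cells (Homo sapiens) for cytotoxicity, read by trypan blue exclusion, with a stated time of 48 h, in the presence of a further agent that is not named here (a higher number here means that more compound is tolerated, a lower number that less compound is tolerated), where compound 3 gives 41500 nM. Its nearest neighbour, compound 2 `COc1ccc2nc(C)cc(OCC(=O)Nc3ccc(Cl)cc3)c2c1`, gives 71100 nM in this assay, and a 1.7-fold lower number from compound 2 to compound 3 (0.23 log units; within the scatter). Compound 1 `COc1ccc2nc(C)cc(OCC(=O)Nc3ccc(Br)cc3)c2c1` gives > 125000 nM in this assay, which is a limit (the limit of > 125000 nM in this assay, at which 1 of the 3 values shown sits). The other steps among these three, an at least 1.7-fold lower number from compound 1 to compound 2 (0.24 log units; that floor lies within the scatter) and an at least 3.0-fold lower number from compound 1 to compound 3 (0.47 log units; beyond the scatter), likewise exchange one group at the same aromatic carbon. Compound 4 `COc1ccc2nc(C)cc(OCC(=O)Nc3ccc(-c4ccccc4)cc3)c2c1` carries phenyl in place of methyl on an aromatic carbon. Among the compounds with values here, no measured step exchanges methyl for phenyl, and the swaps among small groups spanned only a modest range, so the step of a 1.4-fold lower number from compound 3 to compound 4 (0.14 log units; within the scatter) is expected to be small with no clear direction. Compound 4 is estimated at 30000 nM, within 10000 nM to 100000 nM.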

Compound 4, half-maximal cytotoxic concentration: > 126000 nM
Compound 4 ended at the assay's limit; the forecaster's own chance of this, stated with the estimate: 15%; middle value at least 4.2-fold (0.62 log units) away from the limit.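

In this assay compound 4 reads only as a limit: the limit of > 126000 nM in this assay, at which 1 of the 4 values shown sits.

Phenyl in place of methyl gives an at least 3.0-fold higher number from compound 3 to compound 4 (0.48 log units; beyond the scatter), so a large aromatic ring on this carbon does not lower the number, while phenyl in place of chloro gives an at least 1.7-fold higher number from compound 2 to compound 4 (0.24 log units; that floor lies within the scatter). The step between compound 1 and compound 4 cannot be read, since both values are limits.

As far as these compounds go, whether an amine or a carboxylic acid on this carbon would also reach the limit stays open. From the compounds shown here alone, how far compound 1 and compound 4 actually lie from each other also stays open.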